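Trimming the acetyl to a formyl: expected maximal response

This account rests on a few compounds, and the source may have more. Where it says the series, first, only, none or still open, it means among the compounds named here.

Two close relatives of compound 3 have been measured. Compound 1, `CC(Oc1ccccc1Br)C1=NCCN1`, gives 0.4 in an assay on CHO cells with Alpha-2B adrenergic receptor (Homo sapiens) as the target; a higher number here means a larger maximal response, a lower number a smaller maximal response. Compound 2, `CC(=O)c1ccccc1OC(C)C1=NCCN1`, gives 0.6 in this assay. Compound 2 therefore stands highest of the two numbers seen so far, and its nearest neighbour is compound 1, since a number 0.20 higher from compound 1 to compound 2 (beyond the scatter).

Compound 3, `CC(Oc1ccccc1C=O)C1=NCCN1`, is compound 2 with one small change: hydrogen in place of methyl on a carbonyl carbon. Put another way, the acetyl becomes a formyl. Among the compounds with values here, none of the measured steps covers this exact change; the one step in hand, acetyl in place of bromo on an aromatic carbon, was modest and raised the number. A formyl keeps the carbonyl of the acetyl and loses only its methyl, so a step no larger than that one is the most that the data suggest, and its direction is uncertain. The expectation is that the maximal response of compound 3 changes little, a number 0.050 lower from compound 2 to compound 3 (within the scatter), in this assay. Compound 3 is estimated to give 0.55, expected to lie between 0.35 and 0.75.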

Compound 3, intrinsic activity: the largest response reached, as a fraction of the reference agonist's: 0.5
Estimate against measurement, compound 3: 0.050 above; the range from low to high includes it.
By their numbers in this assay, from the lowest: compounds 1, 3 and 2 (each within the scatter of the next, the first and the last beyond it).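

In this assay, hydrogen in place of methyl on the carbonyl carbon gives a number 0.10 lower from compound 2 to compound 3 (within the scatter), so these compounds do not show that the methyl of the acetyl matters for the maximal response. Formyl in place of bromo on the aromatic carbon gives a number 0.10 higher from compound 1 to compound 3 (within the scatter), which leaves compound 3 within the scatter of both compound 1 and compound 2, even though those two differ by more than the scatter; the formyl therefore neither confirms nor rules out that the carbonyl alone accounts for the difference between bromo and acetyl. No measurement at hand offers an explanation for these results.

Still open, going by these compounds, is whether a carbonyl on this aromatic carbon is needed at all, a question that a nitrile or a methoxy group in the same place could help to answer. It is also unclear how the maximal response would respond to a longer chain on the carbonyl carbon, such as propanoyl, or to an amide or a carboxylic acid there.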